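The compounds below may be only part of what the source reports. "The series", "measured", "known", "first", "only" and "open" are said of these compounds alone.

Measured so far:
- compound 1, `O=C(CCCCCC(NC(=O)c1ccc([N+](=O)[O-])cc1)C(=O)NCc1ccccc1)NO`: 9000 nM
- compound 2, `O=C(CCCCC[C@H](NC(=O)c1ccc(Br)cc1)C(=O)NCc1ccccc1)NO`: 5860 nM

Both compounds were tested in a functional assay on NFF cells (Homo sapiens) for antiproliferative activity; a lower number here means a stronger inhibitor, a higher number a weaker inhibitor. Compound 1 gives 9000 nM in this assay, and compound 2 gives 5860 nM. Compound 2 thus carries the lowest of the two numbers shown, but its gap to compound 1 is within the scatter of repeated measurements, so the two cannot be told apart on these data.

Compound 3, `O=C(CCCCC[C@H](NC(=O)c1cc2c(Br)cccc2[nH]1)C(=O)NCc1ccccc1)NO`, has not yet been measured in this assay. It differs from compound 2 in one place: 4-bromo-1H-indol-2-yl in place of 4-bromophenyl on a carbonyl carbon. The rest of the molecule, including the hydroxamic acid end and the benzylamide end, is kept.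

Among the measured compounds shown here, no step between measured compounds is available to say how this kind of change plays out. On the numbers at hand, a small step toward a lower number is expected, of about the size of the scatter or a little more, since compound 2 gives 5860 nM and the group that enters in compound 3 keeps the bromine while adding a larger ring system. Compound 3 is estimated at 3000 nM, within 1000 nM to 9000 nM, which means an expected step of a 2.0-fold lower number from compound 2 to compound 3 (0.29 log units; within the scatter).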

Compound 3, half-maximal inhibitory concentration: 1940 nM
The estimate for compound 3 lay 1.5-fold (0.19 log units) above the measured number; low and high end bracket the measured number.
By their numbers in this assay, from the lowest: compound 3; then compounds 2 and 1 (each within the scatter of the next).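

In this assay, replacing 4-bromophenyl with 4-bromo-1H-indol-2-yl on the carbonyl carbon gives a 3.0-fold lower number from compound 2 to compound 3 (0.48 log units; beyond the scatter). Among the compounds shown here, this is the only step available here, and it shows that the group at this position can change the number by more than the scatter, even with the bromine and the rest of the molecule kept. The change alters several things at once, adding a five-membered aromatic ring with one hetero atom, a hydrogen-bond donor and more heavy atoms, and no measurement here explains the step or singles out one of these changes.

The compounds shown leave open whether the gain follows the second ring or the indole's nitrogen-bound hydrogen: a naphthalen-2-yl group would keep two aromatic rings without that hydrogen, while a 1-methylindol-2-yl group would keep the indole with a methyl group on its nitrogen. They also leave open what the bromine contributes, which a plain 1H-indol-2-yl group would test, and whether the same gain would hold with a longer chain leading to the hydroxamic acid.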